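Fluorophenyl sulfonamide series: 2-fluorophenyl to 3-fluorophenyl

The source may report more compounds than this note shows. Statements on the series, on what has been measured and on what is new or still open speak of the compounds shown alone.

Compound 1 `O=C(NCc1ccc(CNS(=O)(=O)c2ccc3c(c2)CCO3)cc1)c1cccc2c1COC2`: 40%
Compound 2 `O=C(NCc1ccc(CNS(=O)(=O)c2ccccc2F)cc1)c1cc2ccccn2n1`: 40%

In an assay on cells for inhibition of C-X-C chemokine receptor type 4 (Homo sapiens), with a stated time of 22 h, tested at 100 nM (a lower number here means less inhibition, a higher number more inhibition at the concentration tested (going by the name of the read-out)), compound 1 gives 40%, and compound 2 gives 40%, so the two stand level within the scatter. Compound 3 `O=C(NCc1ccc(CNS(=O)(=O)c2cccc(F)c2)cc1)c1cc2ccccn2n1` differs from compound 2 by 3-fluorophenyl in place of 2-fluorophenyl on a sulfonyl sulfur. Within the data shown here, no measured pair shows such a change, so the expected step from compound 2 to compound 3 is small, in no clear direction, and not beyond the scatter. Compound 3 is estimated at 40%, in a range from 20% to 60%. This estimate means an expected step of no change at the digits printed from compound 2 to compound 3 (within the scatter).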

Compound 3, a percentage reported as inhibition, at one concentration (the size of the read-out at that concentration, not a potency): 40%
For compound 3 middle estimate and measured number coincide at the digits printed; the range from low to high includes it.
By their numbers in this assay, from the lowest: compounds 1, 2 and 3 (each within the scatter of the next).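

In this assay the exchange of 3-fluorophenyl for 2-fluorophenyl on a sulfonyl sulfur gives no change at the digits printed from compound 2 to compound 3 (within the scatter), the only one-place comparison among the compounds shown. At the concentration tested, this position therefore does not distinguish these two fluorophenyl groups. Nothing available explains this result.

As far as these compounds go, it remains open whether a phenyl group carrying an amine or a carboxylic acid in place of the fluorine would read differently on the same sulfur. A reading at one concentration also leaves open whether compound 2 and compound 3 match in potency.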